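The source may report more compounds than this note shows. Statements on the series, on what has been measured and on what is new or still open speak of the compounds shown alone.

In a functional assay on HT-29 cells (Homo sapiens) for inhibition, read by sulforhodamine B assay, with a stated time of 48 h (a higher number here means a weaker inhibitor of growth, a lower number a stronger inhibitor of growth), compound 2 `CCCc1ccc(C2NC(=S)NC(C)=C2C(=O)OCC)cc1` gives 50.4 ug/mL. Compound 1 `CCOC(=O)C1=C(C)NC(=S)NC1c1ccc(O)cc1` differs from it in one place, (hydroxy in place of propyl on an aromatic carbon). For compound 1 the assay returns only a limit, > 250 ug/mL. The step of an at least 4.9-fold higher number from compound 2 to compound 1 (0.69 log units; beyond the scatter) is therefore known only as a minimum, since it ends at the limit of > 250 ug/mL in this assay, at which 1 of the 3 values shown sits. Compound 3 `CCCc1ccc(C2NC(=O)NC(C)=C2C(=O)OCC)cc1` has a different core from compound 2; the difference between the two cores is not broken down here. In this assay, within the data shown here, compound 3 gives 17.5 ug/mL, the lowest number so far. Compound 4 `CCOC(=O)C1=C(C)NC(=O)NC1c1ccc(O)cc1` repeats the same change on this core, (hydroxy in place of propyl on an aromatic carbon), at the same place. From compound 3 to compound 4 a step of a 6.9-fold higher number from compound 3 to compound 4 (0.84 log units; beyond the scatter) is expected, resting on the earlier step, which may again end at a limit. Compound 4 is estimated at 120 ug/mL.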

Compound 4, concentration for 50% growth inhibition: 28.7 ug/mL
Estimate against measurement, compound 4: 4.2-fold (0.62 log units) above; the whole stated range lies above it.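

Hydroxy in place of propyl gives a 1.6-fold higher number from compound 3 to compound 4 (0.21 log units; within the scatter) in this assay, so on this core the change leaves no clear mark on the number. The same change does not carry over from one core to the other at the same size: the same change on two cores in this assay, an at least 4.9-fold higher number (0.69 log units; beyond the scatter) from compound 2 to compound 1 and a 1.6-fold higher number (0.21 log units; within the scatter) from compound 3 to compound 4, at least 3.0-fold (0.48 log units) apart, beyond the scatter of two such steps

Compound 1 gives > 250 ug/mL, which is a limit of the assay and not a number, so the true size of the step on its core stays unknown, and one pair on each core cannot explain the gap or set a rule for the series.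

The compounds shown leave open how other groups at this place, such as an amine, a methoxy group or a longer chain, would behave on the two cores. They also leave open whether the gap between the cores would hold for those groups.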